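Ring replacement on the phenylpropyl arm of the cyanoguanidine series

The source may report more compounds than this note shows. Statements on the series, on what has been measured and on what is new or still open speak of the compounds shown alone.

Compound 3 `N#C/N=C(/NCCCCc1c[nH]cn1)NCCCc1ccc(F)cc1` gives 5.28 in an in vitro functional assay on Sf9 cells for antagonist activity at histamine H2 receptor (Homo sapiens); on this read-out higher numbers stand for higher potency (the scale is a negative logarithm) and lower numbers for lower potency. The other two measured compounds lie within the scatter of that number: compound 1 `N#C/N=C(/NCCCCc1c[nH]cn1)NCCCc1ccccc1` at 5.25 and compound 2 `N#C/N=C(\NCCCCc1ccccc1)NCCCCc1c[nH]cn1` at 5.03. All measured steps are small: a number 0.22 log units lower from compound 1 to compound 2 (within the scatter), a number 0.03 log units higher from compound 1 to compound 3 (within the scatter) and a number 0.25 log units higher from compound 2 to compound 3 (within the scatter).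

Compound 4 `N#C/N=C(/NCCCCc1c[nH]cn1)NCCCc1ccccn1` differs from compound 3 by pyridin-2-yl in place of 4-fluorophenyl on a saturated chain carbon, three bonds along the chain from an amine nitrogen. Among the measured compounds shown here, the steps that bear on it are those that alter the aromatic end of the same arm, a number 0.03 log units higher from compound 1 to compound 3 (within the scatter) and a number 0.25 log units higher from compound 2 to compound 3 (within the scatter), neither beyond the scatter. For the measured compounds named here, no measured step exchanges the carbon-only ring for a ring with a hetero atom, so that part of the change has no precedent in this set. Compound 4 is therefore expected near compound 3, with no step beyond the scatter. The estimated step is a number 0.08 log units lower from compound 3 to compound 4 (within the scatter). For compound 4 the estimate in this assay is 5.2, with a range from 4.7 to 5.7.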

Compound 4, negative logarithm of the antagonist equilibrium constant: 5.48
Compound 4: the middle estimate sits 0.28 log units below what was measured; the measured number falls inside the stated range.
By their numbers in this assay, from the lowest: compounds 2, 1, 3 and 4 (each within the scatter of the next, the first and the last beyond it).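

In this assay a ring with a hetero atom is accepted at this place on the saturated chain: the exchange of 4-fluorophenyl for pyridin-2-yl gives a number 0.20 log units higher from compound 3 to compound 4 (within the scatter) and that of phenyl for pyridin-2-yl gives a number 0.23 log units higher from compound 1 to compound 4 (within the scatter) and so neither step separates the two kinds of ring. Among the compounds shown here, the first step in the set to pass the scatter is a number 0.45 log units higher from compound 2 to compound 4 (beyond the scatter) but it remains modest and compares pyridin-2-yl with benzyl, so it changes more than the ring type alone. Nothing available accounts for these steps.

Going by these compounds, whether the place of the ring nitrogen matters remains open, and pyridin-3-yl or pyridin-4-yl would address that. Also open, on these data alone, is whether a thiazol-2-yl ring or a longer chain carrying pyridin-2-yl would stay within the same narrow band.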